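Cytotoxicity notes: fluoro in place of methyl

The compounds below may be only part of what the source reports. "The series", "measured", "known", "first", "only" and "open" are said of these compounds alone.

Compound 1 `C/C(=C\c1cc(-c2ccc(C)cc2)co1)C(N)=O`, compound 2 `C/C(=C\c1cc(-c2cccnc2)co1)C(N)=O` and compound 3 `C/C(=C\c1cc(-c2ccc(C)nc2)co1)C(N)=O` share one core and differ only in the aryl group and its substituent. In an ADME assay on NIH3T3 cells (Mus musculus) for cytotoxicity, read by CCK-8 assay, with a stated time of 24 h (on this read-out lower numbers stand for stronger inhibition and higher numbers for weaker inhibition), compound 1 gives > 50000 nM, which is a limit of the assay and not a number. Compound 2 likewise gives > 50000 nM in this assay, again a limit. Compound 3 gives > 50000 nM in this assay, also a limit. Compound 3 thus stands at the same limit as the two further values shown, and no order among the three can be read. The single-place step that the two limits leave unreadable from compound 2 to compound 3 cannot be sized because of the limit of > 50000 nM in this assay, at which 3 of the 3 values shown sit.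

Compound 4 `C/C(=C\c1cc(-c2ccc(F)nc2)co1)C(N)=O` is not yet measured. It differs from compound 3 by fluoro in place of methyl on an aromatic carbon. Going by the values given here, the only measured step bearing on this position is the methyl step that the two limits leave unreadable from compound 2 to compound 3, which is unreadable; the evidence is only that (the limit of > 50000 nM in this assay, at which 3 of the 3 values shown sit). No readable step exists, so no direction can be derived, and the expected step that the limit leaves unreadable from compound 3 to compound 4 in this assay is none beyond the scatter, with a limit the most likely report. Compound 4 is estimated at 60000 nM in this assay, with a range from 30000 nM to 200000 nM.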

Compound 4, half-maximal inhibitory concentration: > 50000 nM
Compound 4: only a limit was reported (the forecaster's own chance of this, stated with the estimate: 85%); the middle value lies beyond the limit too.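

Compound 4 adds no readable step, and the steps to it from compound 2 and from compound 3 cannot be read: the limit of > 50000 nM in this assay, at which 4 of the 4 values shown sit.

The compounds shown leave open whether any aryl group or substituent on the shared core gives a measured value inside this limit, and with it a step of readable size.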